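The compounds below may be only part of what the source reports. "The series", "measured", "known", "first", "only" and "open" are said of these compounds alone.

In a functional assay on HO8910 cells (Homo sapiens) for cytotoxicity, read by CCK-8 assay, with a stated time of 24 h (on this read-out lower numbers stand for stronger inhibition and higher numbers for weaker inhibition), compound 1 `C/C(=C\c1cc(-c2ccc(F)cc2)cs1)C(N)=O` gives > 50000 nM, and that figure is a limit of the assay rather than a measured number. Compound 1 therefore sits at the limit of > 50000 nM in this assay, at which 1 of the 2 values shown sits. Within the data shown here, compound 2 `C/C(=C\c1cccc(-c2ccccc2)c1)C(N)=O` gives 12600 nM in this assay; no step between compound 1 and compound 2 is counted here, and the two values simply stand side by side. Compound 3 `C/C(=C\c1cc(-c2ccc(C(F)(F)F)cc2)cs1)C(N)=O` has not yet been measured. Compared with compound 1 it shows (trifluoromethyl in place of fluoro on an aromatic carbon), in short trifluoromethyl in place of fluoro on an aromatic carbon, para to a large group. With compound 1 resting at a limit, any expected movement can only be read against that limit. The estimated step is a number no higher from compound 1 to compound 3 (the limit leaves the size open), expected to lie within the usual scatter rather than beyond it. Compound 3 is accordingly estimated at about 50000 nM in this assay, with a range from 15000 nM to 150000 nM, most probably reported again only as a limit.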

Compound 3, half-maximal inhibitory concentration: > 50000 nM
Compound 3: only a limit was reported (the forecaster's own chance of this, stated with the estimate: 60%); the middle value lies on the limit itself.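

Among these compounds, compound 1 and compound 3 are both reported only as limits in this assay, and no step between them can be read. The compounds shown leave open whether trifluoromethyl in place of fluoro on an aromatic carbon changes the read-out at all, and by how much.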